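Swapping Isopropyl for Trifluoromethoxy on the Urea Aryl

The source may hold more compounds than are shown below. What is called first, only, known or untested is meant among the compounds shown, and "the series" means these compounds.

Measured so far in an assay on isolated protein for inhibition of vascular endothelial growth factor receptor 2 (Danio rerio), read by fluorescence and microscopy, with a stated time of 33 h; on this read-out higher numbers stand for weaker inhibition and lower numbers for stronger inhibition:
- Compound 1, `COc1cccc(NC(=O)Nc2ccc(Oc3ncnc4[nH]ncc34)cc2)c1`: compound 1 gives 82000 nM.
- Compound 2, `O=C(NCC1CCCCC1)Nc1ccc(Oc2ncnc3[nH]ncc23)cc1`: compound 2 reaches only the assay limit, > 100000 nM, not a number.
- Compound 3, `CC(C)c1cccc(NC(=O)Nc2ccc(Oc3ncnc4[nH]ncc34)cc2)c1`: compound 3 gives 7730 nM.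

Compound 3 holds the lowest of the two numbers; the nearest is compound 1, with an 11-fold lower number from compound 1 to compound 3 (1.03 log units; beyond the scatter) separating them, and compound 2 sits at the limit (the limit of > 100000 nM in this assay, at which 1 of the 3 values shown sits).

Compound 4, `O=C(Nc1ccc(Oc2ncnc3[nH]ncc23)cc1)Nc1cccc(OC(F)(F)F)c1`, differs from compound 3 by trifluoromethoxy in place of isopropyl on an aromatic carbon. Going by the values given here, the one measured step touching the same aromatic carbon is an 11-fold lower number from compound 1 to compound 3 (1.03 log units; beyond the scatter), where a methoxy-type group was replaced by isopropyl. Trifluoromethoxy returns an oxygen-bearing group to that position, so in this assay a step back toward the number of compound 1 is expected, a 3.2-fold higher number from compound 3 to compound 4 (0.51 log units; beyond the scatter), though its size is uncertain. Compound 4 is therefore estimated at 25000 nM, within 6000 nM to 80000 nM.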

Compound 4, half-maximal inhibitory concentration: 17800 nM
Compound 4: middle estimate off by 1.4-fold (0.15 log units), on the high side; the range from low to high includes it.
By their numbers in this assay, from the lowest: compound 3; then compound 4; then compound 1. At a limit, above all of these: compound 2.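

The oxygen alone does not set the number at this aromatic carbon: in this assay, trifluoromethyl in place of methyl on that oxygen gives a clear gain (a 4.6-fold lower number from compound 1 to compound 4 (0.66 log units; beyond the scatter)). That gain does not reach the isopropyl compound, however (a 2.3-fold higher number from compound 3 to compound 4 (0.36 log units; beyond the scatter)), so an oxygen-linked group can do well here, but neither of the two shown matches isopropyl. Nothing measured here explains the difference between these groups.

On these data alone, whether a tert-butyl group or an amine on the same carbon would give a lower number than compound 3 remains open. So does whether a trifluoromethyl group attached directly to the ring would keep the gain seen with compound 4.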